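This account rests on a few compounds, and the source may have more. Where it says the series, first, only, none or still open, it means among the compounds named here.

Compound 1 `COc1ccc(/C=C/C(=O)c2ccc(OC)c3c2OC(C)(C)C=C3)cc1OCC=C(C)C` has been tested in an ADME assay on L02 cells (Homo sapiens) for cytotoxicity, read by MTT assay; on this read-out higher numbers stand for weaker inhibition and lower numbers for stronger inhibition. In this assay compound 1 gives > 10000 nM, which is a limit of the assay rather than a measured number. Compound 2 `COc1ccc(/C=C/C(=O)c2ccc(OC)c3c2OC(C)(C)C=C3)cc1OC(=O)C1CC1` also stops at a limit, giving > 10000 nM in this assay. The one change among these two, a step that the two limits leave unreadable from compound 1 to compound 2, therefore cannot be sized, because the limit of > 10000 nM in this assay, at which 2 of the 2 values shown sit, holds both values.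

Compound 3 `COc1ccc(/C=C/C(=O)c2ccc(OC)c3c2OC(C)(C)C=C3)cc1OS(=O)(=O)c1ccc(C)cc1` differs from compound 1 by (4-methylphenyl)sulfonyl in place of 3-methylbut-2-en-1-yl on an oxygen on an aromatic ring. For the measured compounds named here, no readable step bears on this change: the only step available, from compound 1 to compound 2, is unreadable for the reason given by the limit of > 10000 nM in this assay, at which 2 of the 2 values shown sit. With both measured compounds resting at the limit, compound 3 is expected to rest there too, so the estimated step that the limit leaves unreadable from compound 1 to compound 3 is no more than scatter. Compound 3 is estimated at 20000 nM, within a range from 7000 nM to 60000 nM.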

Compound 3, half-maximal inhibitory concentration: > 10000 nM
Compound 3 gave a limit, no number; the forecaster's own chance of this, stated with the estimate: 80%; the middle value does not contradict the limit.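

For the compounds shown here, compound 3 stops at a limit as well, so no step between compound 1, compound 2 and compound 3 can be read, because all three values rest at the same limit: the limit of > 10000 nM in this assay, at which 3 of the 3 values shown sit.

The compounds shown leave open whether the three different groups on this oxygen differ at all in this assay.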